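This account rests on a few compounds, and the source may have more. Where it says the series, first, only, none or still open, it means among the compounds named here.

Measured compounds: compound 1 `C[Se]c1ccc(N(C)c2nc(C3CC3)nc3ccccc23)cc1` gives 11 nM in a functional assay on LoVo cells (Homo sapiens) for inhibition, read by MTT assay, with a stated time of 48 h; a higher number here means a weaker inhibitor, a lower number a stronger inhibitor; compound 2 `Cc1nc(N(C)c2ccc([Se]C#N)c(Cl)c2)c2ccccc2n1` gives 12 nM in this assay; compound 3 `C[Se]c1ccc(N(C)c2nc(C)nc3ccccc23)cc1Cl` gives 3 nM in this assay.

The unmeasured compound 4 `CN(c1ccc([Se]C#N)cc1)c1nc(C2CC2)nc2ccccc12` is related to compound 1 by one change, (cyano in place of methyl on a selenium). The same change is already measured once, from compound 3 to compound 2, described as cyano in place of methyl on a selenium, where it made a step of a 4.0-fold higher number from compound 3 to compound 2 (0.60 log units; beyond the scatter). The difference between the core of compound 1 and the core of compound 3 is not broken down here. Compound 1 and compound 2 lie within the usual scatter of each other, while compound 1 and compound 3 are further apart.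

Among the compounds with values here, since the change from compound 1 to compound 4 is the same change, at the same kind of place, as that from compound 3 to compound 2, a step of similar size is expected, though with only one earlier instance the size is uncertain. Compound 4 is therefore expected to give about 44 nM in this assay, a step of a 4.0-fold higher number from compound 1 to compound 4 (0.60 log units; beyond the scatter), somewhere between 15 nM and 130 nM.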

Compound 4, half-maximal inhibitory concentration: 11 nM
For compound 4 the middle estimate is 4.0-fold (0.60 log units) above the measured one; measured number outside the range, below it.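

Placing cyano in place of methyl on a selenium gives, in this assay, no change at the digits printed from compound 1 to compound 4 (within the scatter), so on the core of compound 1 the change leaves no step that can be told from the scatter. The two instances of the change therefore disagree in size: the same change on two cores in this assay, a 4.0-fold higher number (0.60 log units; beyond the scatter) from compound 3 to compound 2 and no change at the digits printed (within the scatter) from compound 1 to compound 4, 4.0-fold (0.60 log units) apart, beyond the scatter of two such steps.

Within the data shown here, this shows that, in this series, the size of the step seen on one core cannot simply be carried over to the other, but with only two pairs it does not show which of the differences between the cores goes with the gap, nor what the change would do on a third core.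

The compounds shown leave open how other groups on the selenium, such as an ethyl group or a longer chain, would compare with methyl and cyano. They also leave open whether the step would stay absent or reappear on a core bearing a further group, such as an amine.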